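Piperazine dithiocarbamates with a benzamide: a ring swap

A few compounds are considered here, and "the series" means these few. Any claim that something is new, unique, unknown or untested is made for them only; others in the source may bear on it.

Measured so far:
compound 1 `Nc1ccccc1NC(=O)c1ccc(CSC(=S)N2CCN(C(c3ccccc3)c3ccccc3)CC2)cc1`, 9.9%
compound 2 `COc1ccc(N2CCN(C(=S)SCc3ccc(C(=O)Nc4ccccc4N)cc3)CC2)cc1`, 22.9%

In a functional assay on MGC-803 cells (Homo sapiens) for antiproliferative activity, read by CCK-8 assay, with a stated time of 72 h, tested at 8 uM (a higher number here means a stronger effect of the compound at the concentration tested, a lower number a weaker effect), compound 2 gives 22.9%, the higher of the two numbers, with compound 1 lower by a gap beyond the scatter. Compound 3 `Nc1ccccc1NC(=O)c1ccc(CSC(=S)N2CCN(c3cccnc3)CC2)cc1` is not yet measured. It differs from compound 2 as follows: pyridin-3-yl in place of 4-methoxyphenyl on an amine nitrogen in a ring. For the measured compounds named here, no step between measured compounds touches this position, so the size of the change cannot be read from the data. A small step, downward or none beyond the scatter, is expected in this assay; the estimated step is a number 6.9 percentage points lower from compound 2 to compound 3 (within the scatter). For compound 3 the estimate is 16%, within 5% to 30%.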

Compound 3, a percentage reported as inhibition, at one concentration (the size of the read-out at that concentration, not a potency): 76.9%
Compound 3: the middle estimate sits 60.9 percentage points below what was measured, and the stated range ends below it.
By their numbers in this assay, from the lowest: compound 1; then compound 2; then compound 3.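

In this assay, placing pyridin-3-yl in place of 4-methoxyphenyl on the amine nitrogen in the ring moves the read-out a number 54 percentage points higher from compound 2 to compound 3 (beyond the scatter). For the compounds shown here, this position is therefore sensitive to the identity of the aromatic ring, which the earlier compounds, with no step between them, could not show. Nothing measured here accounts for the step.

The compounds shown leave open whether the methoxy group or the ring nitrogen carries this step. A plain phenyl or a pyrimidine ring at this position would help separate the two.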